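The compounds below may be only part of what the source reports. "The series", "measured", "known", "first", "only" and "open" are said of these compounds alone.

Among the compounds with values here, compound 1 `CC(C)c1ccc(-c2cc(=O)c3cc(C(=O)O)ccc3o2)cc1` gives 19% in a functional assay on the whole organism (stomach) for inhibition, with Rattus norvegicus as the target, at a dose of 80 mg/kg (a higher number here means more inhibition at the dose given (going by the name of the read-out), a lower number less inhibition), and compound 2 `CC(C)c1ccc(-c2oc3ccc(C(=O)O)cc3c(=O)c2O)cc1` gives 24%; the only one-place step, a number 5 percentage points higher from compound 1 to compound 2 (within the scatter), lies within the scatter. Compound 3 `COc1c(-c2ccc(C)cc2)oc2ccc(C(=O)O)cc2c1=O` gives 4%, the lowest of the three numbers, sitting below compound 1 and further below compound 2. Compound 4 `COc1c(-c2ccc(C(C)C)cc2)oc2ccc(C(=O)O)cc2c1=O` carries one change from compound 3: isopropyl in place of methyl on an aromatic carbon. Within the data shown here, no measured pair differs by this change alone, so nothing measured bears directly on it; compounds 1 and 2 both carry isopropyl and stand higher than compound 3, but they differ from it in more than one place. A modest rise is therefore expected, a number 6 percentage points higher from compound 3 to compound 4 (within the scatter), and compound 4 is estimated at 10%, between 0% and 25%.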

Compound 4, a percentage reported as inhibition, in the whole organism at one dose (the size of the read-out at that dose, not a potency): 18%
Compound 4: middle estimate off by 8 percentage points, on the low side, and the stated range covers the measured number.
By their numbers in this assay, from the lowest: compound 3; then compounds 4, 1 and 2 (each within the scatter of the next).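

With isopropyl in place of methyl on the aromatic carbon para to a large group, this assay shows a number 14 percentage points higher from compound 3 to compound 4 (beyond the scatter) and so responds to this change in size. Once isopropyl is present, methyl on the oxygen gives a number 6 percentage points lower from compound 2 to compound 4 (within the scatter) and methoxy on the aromatic carbon gives a number 1 percentage points lower from compound 1 to compound 4 (within the scatter) so neither change separates these compounds. No measurement at hand explains the step from methyl to isopropyl. The compounds shown leave open how a tert-butyl group, a longer chain or an amine would read at this position. They also leave open whether the isopropyl step would hold without the methoxy group.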